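Alkyl growth on the ring amine of compound 3

The source may hold more compounds than are shown below. What is called first, only, known or untested is meant among the compounds shown, and "the series" means these compounds.

Measured so far in an assay on thoracic aorta (strain Wistar) for antagonist activity at Adrenergic receptor alpha-1 (Rattus norvegicus), with a stated time of 30 min; a higher number here means weaker binding, a lower number tighter binding:
compound 1 `COc1cc2nc(CNc3ccccc3)nc(N)c2cc1OC` — 0.135 nM
compound 2 `COC(=O)c1ccc(NCc2nc(N)c3cc(OC)c(OC)cc3n2)cc1` — 138 nM
compound 3 `COc1cc2nc(N3CCN(C)CC3)nc(N)c2cc1OC` — 0.589 nM

Compound 3 stands second highest of the three numbers in this assay; compound 1 is nearest, with a lower number beyond the scatter, and compound 2 is furthest, with a far higher number. Compound 4 `CCN1CCN(c2nc(N)c3cc(OC)c(OC)cc3n2)CC1` differs from compound 3 by methyl in place of hydrogen on a saturated chain carbon bound to an amine nitrogen in a ring. Within the data shown here, the only measured step, a 1000-fold higher number from compound 1 to compound 2 (3.01 log units; beyond the scatter), concerns a substituent on an aromatic carbon and does not bear on this change; no measured pair probes alkyl growth on the ring amine. A step of a 1.2-fold higher number from compound 3 to compound 4 (0.07 log units; within the scatter) is therefore expected, i.e. none beyond the scatter. For compound 4 the estimate is 0.7 nM, with a range of 0.25 nM to 2 nM.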

Compound 4, dissociation constant: 0.0389 nM
Compound 4: middle estimate off by 18-fold (1.26 log units), on the high side; measured number below the stated range.
By their numbers in this assay, from the lowest: compound 4; then compound 1; then compound 3; then compound 2.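

Methyl in place of hydrogen on a saturated chain carbon bound to an amine nitrogen in a ring gives a 15-fold lower number from compound 3 to compound 4 (1.18 log units; beyond the scatter) in this assay. This position therefore responds strongly to a methyl to ethyl change, which the earlier step, on an aromatic carbon, could not show. Nothing available explains this shift. The compounds shown leave open whether a longer chain such as propyl, or a branched group such as isopropyl, on that amine nitrogen would lower the number further or raise it again.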